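A few compounds are considered here, and "the series" means these few. Any claim that something is new, unique, unknown or untested is made for them only; others in the source may bear on it.

Three compounds have been measured in a functional assay on HepG2 cells (Homo sapiens) for inhibition, read by MTT assay, with a stated time of 72 h; a higher number here means a weaker inhibitor, a lower number a stronger inhibitor:
compound 1 `CC(C)(C)n1cc2c(n1)C(=O)CC1(CCN(C(=O)c3cc(-c4ccccc4)nc4ccccc34)CC1)O2` — 2110 nM
compound 2 `CC(C)(C)n1cc2c(n1)C(=O)CC1(CCN(C(=O)c3cc(-c4ccc(F)cc4)nc4ccccc34)CC1)O2` — 2930 nM
compound 3 `CC(C)(C)n1cc2c(n1)C(=O)CC1(CCN(C(=O)c3cc(-c4ccc(Br)cc4)nc4ccccc34)CC1)O2` — 820 nM

Among these, compound 3 gives the lowest number: a 2.6-fold lower number from compound 1 to compound 3 (0.41 log units; beyond the scatter), and a 3.6-fold lower number from compound 2 to compound 3 (0.55 log units; beyond the scatter), while a 1.4-fold higher number from compound 1 to compound 2 (0.14 log units; within the scatter). Compound 4 `CN1CCN(c2cc(C(=O)N3CCC4(CC3)CC(=O)c3nn(C(C)(C)C)cc3O4)c3ccccc3n2)CC1` has not yet been measured in this assay. It differs from compound 3 in one place: 4-methylpiperazin-1-yl in place of 4-bromophenyl on an aromatic carbon. Among the compounds with values here, none of the measured steps bears directly on this change; all three swap one substituent for another on the 4-bromophenyl group that now leaves entirely, and the largest of them was the modest 3.6-fold lower number from compound 2 to compound 3 (0.55 log units; beyond the scatter). With no guide to a change of this kind, the value of compound 3 is the only anchor, and a wide spread in either direction is expected, with a weaker inhibitor somewhat more likely than a stronger one. For compound 4 the estimate in this assay is 2500 nM, within 600 nM to 10000 nM, meaning an expected step of a 3.0-fold higher number from compound 3 to compound 4 (0.48 log units; beyond the scatter).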

Compound 4, half-maximal inhibitory concentration: 9550 nM
The estimate for compound 4 lay 3.8-fold (0.58 log units) below the measured number; measured number inside the range.
By their numbers in this assay, from the lowest: compound 3; then compounds 1 and 2 (each within the scatter of the next); then compound 4.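

In this assay, all three phenyl-type groups at this position give lower numbers than 4-methylpiperazin-1-yl, with a 12-fold higher number from compound 3 to compound 4 (1.07 log units; beyond the scatter), a 3.3-fold higher number from compound 2 to compound 4 (0.51 log units; beyond the scatter) and a 4.5-fold higher number from compound 1 to compound 4 (0.66 log units; beyond the scatter). The position therefore responds to exchanging the whole ring, and the step from the 4-bromophenyl compound is the only one so far graded large. Nothing available explains this difference.

The compounds shown leave open whether the higher number follows the ring nitrogens or the non-aromatic ring. A pyridin-4-yl or a piperidin-1-yl group at this position would separate the two.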